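Sulfonyl amine variations on the dioxane benzamide series

The source may hold more compounds than are shown below. What is called first, only, known or untested is meant among the compounds shown, and "the series" means these compounds.

Measured so far in an assay on isolated protein for inhibition of 5-hydroxytryptamine receptor 4 (Homo sapiens); a lower number here means a stronger inhibitor, a higher number a weaker inhibitor:
compound 1 `CC(C)N1CCN(S(=O)(=O)CCCN2CCC(CNC(=O)c3cccc4c3OCCO4)CC2)CC1` gives 0.0316 nM
compound 2 `CC1(C)CCN(S(=O)(=O)CCCN2CCC(CNC(=O)c3cccc4c3OCCO4)CC2)CC1` gives 0.126 nM
compound 3 `O=C(NCC1CCN(CCCS(=O)(=O)N2CCN(Cc3cccnc3)CC2)CC1)c1cccc2c1OCCO2` gives 0.159 nM

Compound 2 holds the second highest of the three numbers in this assay. Its nearest neighbour is compound 3, whose value sits within the scatter of that of compound 2, so no order between the two can be claimed. Among the measured compounds shown here, the only step beyond the scatter from compound 2 runs to compound 1, which gives the lowest number of the three: a 4.0-fold higher number from compound 1 to compound 2 (0.60 log units; beyond the scatter).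

Compound 4 `O=C(NCC1CCN(CCCS(=O)(=O)N2CCNCC2)CC1)c1cccc2c1OCCO2` is next for this assay. The change from compound 2 is piperazin-1-yl in place of 4,4-dimethylpiperidin-1-yl on a sulfonyl sulfur.

For the measured compounds named here, two measured steps bear on it. The step of a 4.0-fold higher number from compound 1 to compound 2 (0.60 log units; beyond the scatter) covers the same position on the sulfonyl sulfur and shows that the ring there matters at a modest level; compound 4 brings a piperazine ring back, as in compound 1, but without the group on the ring nitrogen. The step of a 5.0-fold higher number from compound 1 to compound 3 (0.70 log units; beyond the scatter) shows that what sits on that ring nitrogen also moves the number modestly. With the ring restored and the nitrogen substituent removed, the two influences pull in opposite directions, and the expected net step from compound 2 to compound 4 is a 1.6-fold higher number from compound 2 to compound 4 (0.20 log units; within the scatter), not beyond the scatter. Compound 4 is therefore estimated at 0.2 nM, within a range of 0.05 nM to 0.8 nM.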

Compound 4, inhibition constant: 0.159 nM
Beside the measured number, compound 4's estimate is 1.3-fold (0.10 log units) above it; low and high end bracket the measured number.
By their numbers in this assay, from the lowest: compound 1; then compounds 2, 3 and 4 (each within the scatter of the next).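

In this assay, piperazin-1-yl on the sulfonyl sulfur, with 1 hydrogen-bond donor and 1 hydrogen-bond acceptor, and 4,4-dimethylpiperidin-1-yl, with 0 of each, cannot be told apart: the change gives a 1.3-fold higher number from compound 2 to compound 4 (0.10 log units; within the scatter). On the ring nitrogen, hydrogen in place of isopropyl gives a 5.0-fold higher number from compound 1 to compound 4 (0.70 log units; beyond the scatter), whereas hydrogen in place of (pyridin-3-yl)methyl gives no change at the digits printed from compound 3 to compound 4 (within the scatter). The gap between compound 1 and compound 2 therefore no longer reads as an effect of the piperazine ring alone, since the unsubstituted piperazine of compound 4 does not share the low number of compound 1, and among these piperazines the isopropyl group of compound 1 is the one substituent on that nitrogen that stands apart.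

The compounds shown leave open whether a methyl, cyclopropyl or tert-butyl group on the ring nitrogen would keep the number of compound 1, or whether isopropyl is a narrow optimum. They also leave open how an acetyl group at that nitrogen, or a morpholin-4-yl ring on the sulfonyl sulfur, would compare. Nothing at hand gives a reason for these results.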